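Side-chain amide extension on compound 2

A few compounds are considered here, and "the series" means these few. Any claim that something is new, unique, unknown or untested is made for them only; others in the source may bear on it.

Of the compounds shown here, three on one shared core have been measured in a functional assay on HT-29 cells (Homo sapiens) for inhibition, read by CellTiter-Glo, with a stated time of 72 h; a lower number here means that less compound is tolerated, a higher number that more compound is tolerated. Compound 1 `CC1=C(C(C)C(=O)NCCN(C)C)c2cc(F)ccc2/C1=C\c1ccc([S+](C)[O-])cc1` gives 12700 nM; compound 2 `CC1=C(C(C)C(=O)N(C)CCN(C)C)c2cc(F)ccc2/C1=C\c1ccc([S+](C)[O-])cc1` gives 11900 nM; compound 3 `CC1=C(C(C)C(=O)N(CCNC(C)C)C(C)C)c2cc(F)ccc2/C1=C\c1ccc([S+](C)[O-])cc1` gives 8060 nM. The steps between them are small: a 1.1-fold lower number from compound 1 to compound 2 (0.03 log units; within the scatter), a 1.6-fold lower number from compound 1 to compound 3 (0.20 log units; within the scatter) and a 1.5-fold lower number from compound 2 to compound 3 (0.17 log units; within the scatter), each within the scatter. Compound 2 thus stands second highest of the three numbers, nearest to compound 1 and furthest from compound 3, with neither gap beyond the scatter.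

Compound 4 `CC1=C(C(C)C(=O)N(C)CCN(C)C(=O)[C@@H](N)C(C)C)c2cc(F)ccc2/C1=C\c1ccc([S+](C)[O-])cc1` differs from compound 2 by (1-amino-2-methylpropyl)carbonyl in place of methyl on an amine nitrogen. All three measured steps alter the same amide side chain, and none of them moved this assay beyond the scatter, so variation at that end of the molecule has so far left the read-out flat. The change to compound 4 is larger in what enters than any of those steps, but nothing measured points in a direction. Compound 4 is therefore expected near 12000 nM, in the range 5000 nM to 30000 nM. The expected step of a 1.0-fold higher number from compound 2 to compound 4 (0.00 log units; within the scatter) is estimated not to exceed the scatter.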

Compound 4, half-maximal cytotoxic concentration: 26000 nM
Compound 4: the middle estimate sits 2.2-fold (0.34 log units) below what was measured; low and high end bracket the measured number.
By their numbers in this assay, from the lowest: compounds 3, 2 and 1 (each within the scatter of the next); then compound 4.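

In this assay, among these compounds, (1-amino-2-methylpropyl)carbonyl in place of methyl on the amine nitrogen gives a 2.2-fold higher number from compound 2 to compound 4 (0.34 log units; beyond the scatter) and is the first step to lie beyond the scatter, though only modestly. The earlier steps on the same side chain left the read-out flat, so this amine nitrogen is the first place shown where a substitution shifts the number, in the direction of more compound tolerated. Nothing available explains the shift.

The compounds shown leave open whether the shift follows from the carbonyl on this nitrogen alone or also requires the primary amine and the branched isopropyl end, which an acetyl or aminoacetyl group on the same nitrogen would separate. On these data alone, the role of the defined stereocentre also remains open, as the opposite configuration does not appear among them.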